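The source may hold more compounds than are shown below. What is called first, only, known or untested is meant among the compounds shown, and "the series" means these compounds.

Measured compounds:
compound 1 `O=[N+]([O-])c1cccc(CNc2cc(C(F)(F)F)cc3[nH]ncc23)c1` with 45%
compound 2 `FC(F)(F)c1cccc(CNc2cc(C(F)(F)F)cc3[nH]ncc23)c1` with 25%

Compound 1 and compound 2 share a core and differ only in one group on the benzylic ring. Among the measured compounds shown here, in an assay for inhibition of Indoleamine 2,3-dioxygenase 1 (Homo sapiens), with stated times of 10 min and 60 min, tested at 10 uM (on this read-out lower numbers stand for a weaker effect and higher numbers for a stronger effect at the one concentration tested), compound 1 gives 45%, and compound 2 gives 25%, the lower of the two numbers; the single step, a number 20 percentage points lower from compound 1 to compound 2 (beyond the scatter), is beyond the scatter.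

Compound 3 `O=C(O)c1cccc(CNc2cc(C(F)(F)F)cc3[nH]ncc23)c1` has not yet been measured in this assay. It differs from compound 2 by carboxy in place of trifluoromethyl on an aromatic carbon. For the measured compounds named here, no measured step concerns this change; the one step, a number 20 percentage points lower from compound 1 to compound 2 (beyond the scatter), swaps different groups at the same place and shows only that the read-out there moves modestly. Compound 3 is therefore expected to stay near compound 2, with no change at the digits printed from compound 2 to compound 3 (within the scatter) within the scatter, and an estimated 25%, ranging from 5% to 50%.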

Compound 3, a percentage reported as inhibition, at one concentration (the size of the read-out at that concentration, not a potency): 11%
Compound 3: the middle estimate sits 14 percentage points above what was measured, within the range that was stated.
By their numbers in this assay, from the lowest: compound 3; then compound 2; then compound 1.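

In this assay carboxy in place of trifluoromethyl gives a number 14 percentage points lower from compound 2 to compound 3 (beyond the scatter) and carboxy in place of nitro gives a number 34 percentage points lower from compound 1 to compound 3 (beyond the scatter). This position therefore tolerates less than the first pair alone suggested, as the three groups now spread over a wider span, running from carboxy at the bottom through trifluoromethyl to nitro at the top. No measurement at hand explains why the groups fall in this order.

As far as these compounds go, it remains open whether an amine, an amide or a nitrile at the same place would lift the read-out above that of compound 1 or leave it lower. From the compounds shown here alone, it is also open whether the same order of groups would hold if the trifluoromethyl on the shared core gave way to another group.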